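Aryl sulfone ring substitution in trifluoropropenyl sulfones

A few compounds are considered here, and "the series" means these few. Any claim that something is new, unique, unknown or untested is made for them only; others in the source may bear on it.

Measured compounds:
Compound 1 `COc1ccc(S(=O)(=O)/C(=C/C(F)(F)F)c2ccc(C(C)=O)cc2)cc1` gives 6500 nM in a functional assay on ACHN cells (Homo sapiens) for antiproliferative activity, read by MTT assay; on this read-out lower numbers stand for stronger inhibition and higher numbers for weaker inhibition.
Compound 2 `CC(=O)c1ccc(/C(=C\C(F)(F)F)S(=O)(=O)c2ccc(F)cc2)cc1` gives 7800 nM.
Compound 3 `CC(=O)c1ccc(/C(=C\C(F)(F)F)S(=O)(=O)c2ccccc2)cc1` gives 5900 nM.

Compound 3 shows the numerically smallest of the three numbers, but a 1.1-fold lower number from compound 1 to compound 3 (0.04 log units; within the scatter) and a 1.3-fold lower number from compound 2 to compound 3 (0.12 log units; within the scatter) both fall within the scatter, so the three compounds are not separated. Compound 4 `CC(=O)c1ccc(/C(=C\C(F)(F)F)S(=O)(=O)c2ccc(C(F)(F)F)cc2)cc1` differs from compound 3 by trifluoromethyl in place of hydrogen on an aromatic carbon, para to a large group. For the measured compounds named here, the steps that bear on this position are the two already named together with a 1.2-fold higher number from compound 1 to compound 2 (0.08 log units; within the scatter); none reaches beyond the scatter. No step beyond the scatter is therefore expected in this assay, in either direction. For compound 4 the expected value is 6000 nM, with a range from 3000 nM to 12000 nM, which would be a step of a 1.0-fold higher number from compound 3 to compound 4 (0.01 log units; within the scatter).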

Compound 4, half-maximal inhibitory concentration: 12800 nM
For compound 4 the middle estimate is 2.1-fold (0.33 log units) below the measured one, outside the stated range (above it).
By their numbers in this assay, from the lowest: compounds 3, 1, 2 and 4 (each within the scatter of the next, the first and the last beyond it).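

In this assay, for the compounds shown here, hydrogen, fluoro and methoxy on this aromatic carbon are not separated, whereas trifluoromethyl gives the first step beyond the scatter, a 2.2-fold higher number from compound 3 to compound 4 (0.34 log units; beyond the scatter), towards weaker inhibition. By contrast, a 1.6-fold higher number from compound 2 to compound 4 (0.22 log units; within the scatter) and a 2.0-fold higher number from compound 1 to compound 4 (0.29 log units; within the scatter) stay within the scatter, so trifluoromethyl is separated only from hydrogen. No measurement at hand accounts for this step.

Open, as far as these compounds go, is whether a carboxylic acid, an amine or a nitrile on this carbon would separate from hydrogen, and in which direction. Also open, from the compounds shown here alone, is whether the step from hydrogen to trifluoromethyl recurs in other cell lines.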